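Moving the Chlorine Around the Ring: Compound 3

The source may report more compounds than this note shows. Statements on the series, on what has been measured and on what is new or still open speak of the compounds shown alone.

Measured so far:
compound 1 `CCC(C(=O)N1CCN(c2ccccc2Cl)CC1)N1C(=O)CCC1=O` — 25%
compound 2 `CCC(C(=O)N1CCN(c2cccc(Cl)c2)CC1)N1C(=O)CCC1=O` — 50%

Among the compounds with values here, in a functional assay on the whole organism (strain Swiss) with Mus musculus as the target, in the maximal electroshock model, with a stated time of 0.5 h, at a dose of 300 mg/kg by the intraperitoneal route (on this read-out higher numbers stand for a stronger effect at the one dose given and lower numbers for a weaker effect), compound 2 gives 50%, the highest of the two numbers known; its only neighbour is compound 1, which gives 25%. Within the data shown here, the single measured step, a number 25 percentage points higher from compound 1 to compound 2 (beyond the scatter), came from 3-chlorophenyl in place of 2-chlorophenyl on an amine nitrogen in a ring.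

Compound 3 `CCC(C(=O)N1CCN(c2ccc(Cl)cc2)CC1)N1C(=O)CCC1=O` is not yet measured. It differs from compound 2 by 4-chlorophenyl in place of 3-chlorophenyl on an amine nitrogen in a ring. Among the measured compounds shown here, no measured step involves 4-chlorophenyl, so the expectation rests on the one step above, which was modest and upward; a second shift of the chlorine could continue that or reverse it, and the data do not decide. Compound 3 is therefore estimated to give 50%, ranging from 25% to 75%. The expected step, no change at the digits printed from compound 2 to compound 3 (within the scatter), is none beyond the scatter.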

Compound 3, a percentage reported as activity, at one dose (the size of the read-out at that dose, not a potency): 0%
The estimate for compound 3 lay 50 percentage points above the measured number; measured number below the stated range.
By their numbers in this assay, from the lowest: compound 3; then compound 1; then compound 2.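

In this assay the place of the chlorine counts for more than the earlier step could show: there is a number 50 percentage points lower from compound 2 to compound 3 (beyond the scatter) when 4-chlorophenyl replaces 3-chlorophenyl, and a number 25 percentage points lower from compound 1 to compound 3 (beyond the scatter) when it replaces 2-chlorophenyl. The entering and leaving groups have the same atoms and the same counts, so only the place of the chlorine differs, and the read-out does not climb steadily along the series: 3-chlorophenyl stands above both other placements. Nothing available here explains this order.

From the compounds shown here alone, whether a 3-methoxyphenyl or 3-fluorophenyl group on the same ring nitrogen would keep the effect seen with 3-chlorophenyl remains open, as does the result for a plain phenyl group. With only one dose and one time shown, how these three compounds would rank under other conditions also remains open.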